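A few compounds are considered here, and "the series" means these few. Any claim that something is new, unique, unknown or untested is made for them only; others in the source may bear on it.

Measured so far in a functional assay on MCF7 cells (Homo sapiens) for inhibition, read by MTT assay, with a stated time of 48 h; on this read-out lower numbers stand for stronger inhibition and higher numbers for weaker inhibition:
compound 1 `COc1ccc(-c2cc(/C=C/C(=O)c3ccc(N)cc3)[nH]n2)cc1` gives 800 nM
compound 2 `COc1cc(-c2cc(/C=C/C(=O)c3ccc(N)cc3)[nH]n2)cc(OC)c1OC` gives 1600 nM
compound 3 `COc1ccc2c(c1)C/C(=C\c1cc(-c3cc(OC)c(OC)c(OC)c3)n[nH]1)C2=O` gives 2100 nM

For the measured compounds named here, all three numbers in this assay sit within the usual scatter of one another, so compound 2 is not set apart from compound 1 or compound 3 by these data; no step between any of them counts as a real difference.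

Compound 4 `COc1cc(-c2cc(/C=C/C(=O)c3ccc(Cl)c(Cl)c3)[nH]n2)cc(OC)c1OC` is not yet measured. It differs from compound 2 by 3,4-dichlorophenyl in place of 4-aminophenyl on a carbonyl carbon. Going by the values given here, no measured pair tells what such a change does, so the expectation rests on compound 2 alone. The step of no change at the digits printed from compound 2 to compound 4 (within the scatter) is expected to stay within the scatter, with no clear direction. Compound 4 is therefore estimated at 1600 nM, within the range 500 nM to 5000 nM.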

Compound 4, half-maximal inhibitory concentration: 3200 nM
Beside the measured number, compound 4's estimate is 2.0-fold (0.30 log units) below it; the range from low to high includes it.
By their numbers in this assay, from the lowest: compounds 1, 2, 3 and 4 (each within the scatter of the next, the first and the last beyond it).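

In this assay, the group on the carbonyl carbon now has its first one-place comparison: 3,4-dichlorophenyl in place of 4-aminophenyl gives a 2.0-fold higher number from compound 2 to compound 4 (0.30 log units; within the scatter). Exchanging the hydrogen-bond donor and acceptor of 4-aminophenyl for two chlorines therefore does not separate compound 4 from compound 2 on this read-out. No available measurement offers an explanation for this result.
Still open, as far as these compounds go, is whether a carboxylic acid, a hydroxyl or a single chlorine on this phenyl ring would give a number beyond the scatter. Also open, from the compounds shown here alone, is how a morpholine in place of the ring would read.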